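Swapping Trifluoromethyl for Methoxy on the Shared Core

The compounds below may be only part of what the source reports. "The series", "measured", "known", "first", "only" and "open" are said of these compounds alone.

Compound 1 `FC(F)(F)c1ccc(C2CC(c3ccc4c(c3)OCCO4)=NN2c2ccccc2)cc1` carries a trifluoromethyl group on the aryl ring bound to the saturated ring carbon of the shared core. In a functional assay on WM 266-4 cells (Homo sapiens) for antiproliferative activity, read by MTT assay, with a stated time of 24 h (on this read-out higher numbers stand for weaker inhibition of growth and lower numbers for stronger inhibition of growth), compound 1 gives > 100000 nM, which is a limit of the assay rather than a number, so compound 1 stands at the weak end of what was measured (the limit of > 100000 nM in this assay, at which 1 of the 3 values shown sits). Compound 2 `Ic1ccc(C2CC(c3ccc4c(c3)OCCO4)=NN2c2ccccc2)cc1` is the iodo analogue, and in this assay compound 2 gives 3470 nM. Compound 3 `c1ccc(N2N=C(c3ccc4c(c3)OCCO4)CC2c2ccc3ccccc3c2)cc1` replaces the whole aryl group with naphthalen-2-yl, and in this assay compound 3 gives 13900 nM. The step of an at least 28-fold lower number from compound 1 to compound 2 (1.45 log units; beyond the scatter) and the step of an at least 7.1-fold lower number from compound 1 to compound 3 (0.85 log units; beyond the scatter) both move away from the trifluoromethyl-bearing compound and both lower the number beyond the scatter, while between the two replacements the number shifts as in a 4.0-fold higher number from compound 2 to compound 3 (0.60 log units; beyond the scatter).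

Compound 4 `COc1ccc(C2CC(c3ccc4c(c3)OCCO4)=NN2c2ccccc2)cc1` has not yet been measured. It differs from compound 1 in one place: methoxy in place of trifluoromethyl on an aromatic carbon. Both measured steps that start from compound 1 removed the trifluoromethyl group and lowered the number, so a lower number is expected for compound 4 as well, though the starting value is only a limit and the size of the step is uncertain. Compound 4 is therefore expected to show an at least 8.3-fold lower number from compound 1 to compound 4 (0.92 log units; beyond the scatter) in this assay. The estimate for compound 4 is 12000 nM, with a range from 2500 nM to 70000 nM.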

Compound 4, concentration for 50% growth inhibition: > 100000 nM
Compound 4 gave a limit, no number; the forecaster's own chance of this, stated with the estimate: 20%; middle value at least 8.3-fold (0.92 log units) away from the limit.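

In this assay compound 4 gives > 100000 nM, which is a limit of the assay and not a number, so taking trifluoromethyl off this aromatic carbon does not by itself bring the number into the measurable range. What enters therefore matters as well as what leaves: methoxy in place of iodo gives an at least 28-fold higher number from compound 2 to compound 4 (1.45 log units; beyond the scatter), and 4-methoxyphenyl in place of naphthalen-2-yl on the saturated ring carbon gives an at least 7.1-fold higher number from compound 3 to compound 4 (0.85 log units; beyond the scatter), so among the four compounds only the iodo and naphthalen-2-yl compounds give a number. The step between compound 1 and compound 4 cannot be read, as both values are limits, and the two compounds sit at the same edge of the assay: the limit of > 100000 nM in this assay, at which 2 of the 4 values shown sit.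

On these data alone, whether the measurable number of compound 2 is particular to iodo or also appears with chloro or bromo on the same aromatic carbon remains open, as does what an amine or a carboxylic acid would do there. As far as these compounds go, how far compound 1 and compound 4 lie beyond their shared limit also remains unknown, so any order between them stays undetermined.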